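A few compounds are considered here, and "the series" means these few. Any claim that something is new, unique, unknown or untested is made for them only; others in the source may bear on it.

Compound 1, `CN(C)C(=O)CN1CCC(c2cc3c(-c4ccc(=O)n(C5CCOCC5)c4)ccnc3[nH]2)CC1`, gives 840000 nM in a physicochemical assay for solubility, in phosphate buffer, at pH 7.4; a higher number here means a more soluble compound, a lower number a less soluble compound.
Compound 2, `CC(C)n1cc(-c2ccnc3[nH]c(C4CCN(CC(=O)N5CCCC5)CC4)cc23)ccc1=O`, gives 260000 nM in this assay.
Compound 3, `COc1cc(C(=O)N2CCCC2)ccc1-c1ccnc2[nH]c(C3CCNCC3)cc12`, gives 590000 nM in this assay.

Compound 1 has the highest of the three numbers. Compound 3 is nearest to it, and the two are within the usual scatter of each other, so nothing separates them. Compound 2 is furthest from compound 1, and that gap is beyond the scatter. No two of these compounds differ in a single place, so no step between measured compounds can be read off.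

Compound 4, `CCn1cc(-c2ccnc3[nH]c(C4CCN(CC(=O)N(C)C)CC4)cc23)ccc1=O`, has not yet been measured in this assay. It differs from compound 1 as follows: ethyl in place of oxan-4-yl on an aromatic nitrogen. Compound 2, which carries a smaller group on the same aromatic nitrogen, gives 260000 nM, and that points to a lower number for compound 4 than for compound 1, by a step that may reach beyond the scatter but is not expected to be large. The estimate for compound 4 is therefore 400000 nM, within a range from 150000 nM to 900000 nM, which means an expected step of a 2.1-fold lower number from compound 1 to compound 4 (0.32 log units; beyond the scatter).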

Compound 4, solubility: > 1000000 nM
Compound 4 gave a limit, no number; the forecaster's own chance of this, stated with the estimate: 5%; middle value at least 2.5-fold (0.39 log units) away from the limit.
By their numbers in this assay, from the lowest: compound 2; then compounds 3 and 1 (each within the scatter of the next). At a limit, above all of these: compound 4.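

Compound 4 gives > 1000000 nM in this assay, and this value is a limit of the assay, not a number. Within the data shown here, for ethyl in place of oxan-4-yl on this aromatic nitrogen, the one direct reading is an at least 1.1-fold higher number from compound 1 to compound 4 (0.07 log units; that floor lies within the scatter), so the ring is not needed to keep the read-out at the level of compound 1, though the true size of the step stays unknown. The step can be read only as a floor because of a limit: the limit of > 1000000 nM in this assay, at which 1 of the 4 values shown sits.

The compounds shown leave open how methyl, a longer chain such as n-butyl, or a chain ending in an amine or a carboxylic acid would read on this nitrogen. They also leave open whether the same change reads the same way when the dimethylamide of compound 1 is replaced by another amide.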